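Aryl exchange on the way to compound 4

The source may hold more compounds than are shown below. What is called first, only, known or untested is meant among the compounds shown, and "the series" means these compounds.

In a functional assay on Caco-2 cells (Homo sapiens) for inhibition, read by MTT assay, with a stated time of 48 h, tested at 10 uM (on this read-out higher numbers stand for more inhibition of growth at the one concentration tested and lower numbers for less inhibition of growth), compound 1 `Cc1oc2c([C@H]3CCN(C)C[C@H]3O)c(O)cc(O)c2c(=O)c1C(O)c1c(F)cccc1Cl` gives 18%, compound 2 `Cc1oc2c([C@H]3CCN(C)C[C@H]3O)c(O)cc(O)c2c(=O)c1C(O)c1cc(F)cc(F)c1` gives 10% and compound 3 `CCOc1ccc(Br)c(C(O)c2c(C)oc3c([C@H]4CCN(C)C[C@H]4O)c(O)cc(O)c3c2=O)c1` gives 5%. Compound 3 cannot be separated from compound 2, with a number 5 percentage points lower from compound 2 to compound 3 (within the scatter), and stands apart only from compound 1, with a number 13 percentage points lower from compound 1 to compound 3 (beyond the scatter).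

Compound 4 `Cc1oc2c([C@H]3CCN(C)C[C@H]3O)c(O)cc(O)c2c(=O)c1C(O)c1ccc(F)cc1` has 4-fluorophenyl in place of 2-bromo-5-ethoxyphenyl on a saturated chain carbon bound to an aromatic carbon and an oxygen on a saturated carbon.

All three measured steps are exchanges at this same place. The other one is a number 8 percentage points lower from compound 1 to compound 2 (within the scatter). The closest measured group to 4-fluorophenyl is the 3,5-difluorophenyl of compound 2, and compound 2 shows 10%. For the measured compounds named here, no 4-fluorophenyl analogue has been measured, so this comparison is only indirect. No step beyond the scatter is expected in this assay. The expected step is a number 5 percentage points higher from compound 3 to compound 4 (within the scatter). For compound 4 the estimate is 10%, with an expected range of 3% to 20%.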

Compound 4, percent growth inhibition at one concentration: 11%
Compound 4: the middle estimate sits 1 percentage points below what was measured, and the stated range covers the measured number.
By their numbers in this assay, from the lowest: compounds 3, 2, 4 and 1 (each within the scatter of the next, the first and the last beyond it).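

In this assay, 4-fluorophenyl cannot be separated from any of the other three aryl groups at this place: a number 6 percentage points higher from compound 3 to compound 4 (within the scatter), a number 1 percentage points higher from compound 2 to compound 4 (within the scatter) and a number 7 percentage points lower from compound 1 to compound 4 (within the scatter). For the compounds shown here, compound 4 therefore lies within the scatter of every earlier compound, and the single step beyond the scatter, between compound 1 and compound 3, now stands as the only separation in the set, with no aryl exchange involving 4-fluorophenyl reaching that size. No measurement available here accounts for how closely these aryl groups read.

On these data alone, all four compounds carry a halogen-bearing phenyl ring at this place, so the effect of a pyridine ring, or of an aminomethyl or carboxylic acid group on the ring, remains open. As far as these compounds go, each number also comes from one concentration, so how these compounds compare across a range of concentrations remains open too.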